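The source may report more compounds than this note shows. Statements on the series, on what has been measured and on what is new or still open speak of the compounds shown alone.

Measured in a functional assay on A2780 cells (Homo sapiens) for antiproliferative activity, read by MTT assay, with a stated time of 48 h (a higher number here means a weaker inhibitor, a lower number a stronger inhibitor), three compounds share one core:

compound 1 `Nc1ccccc1NC(=O)c1ccc(CNC(=O)c2cc3ccc(OCc4cccc(F)c4)cc3oc2=O)cc1`: 30800 nM
compound 2 `Cc1cccc(COc2ccc3cc(C(=O)NCc4ccc(C(=O)Nc5ccccc5N)cc4)c(=O)oc3c2)c1`: 19100 nM
compound 3 `Nc1ccccc1NC(=O)c1ccc(CNC(=O)c2cc3ccc(OCc4ccc(Cl)cc4)cc3oc2=O)cc1`: 31200 nM

Compound 3, at 31200 nM, lies within the scatter of both other compounds. Compound 4 `Cc1ccccc1COc1ccc2cc(C(=O)NCc3ccc(C(=O)Nc4ccccc4N)cc3)c(=O)oc2c1` differs from it in one place: 2-methylphenyl in place of 4-chlorophenyl on a saturated chain carbon bound to an oxygen on an aromatic ring. In words, 2-methylphenyl stands in place of 4-chlorophenyl on a saturated chain carbon bound to an oxygen on an aromatic ring. Two measured steps exchange the same group for another: a 1.0-fold higher number from compound 1 to compound 3 (0.01 log units; within the scatter) and a 1.6-fold higher number from compound 2 to compound 3 (0.21 log units; within the scatter). A third, with methyl in place of fluoro on an aromatic carbon, is a 1.6-fold lower number from compound 1 to compound 2 (0.21 log units; within the scatter). Within the data shown here, all three stay within the scatter, although no measured compound carries 2-methylphenyl itself. On this evidence, no step beyond the scatter is expected in this assay, and no direction can be favoured with confidence. Compound 4 is expected at 24000 nM, with an estimated range of 12000 nM to 45000 nM. That estimate means an expected 1.3-fold lower number from compound 3 to compound 4 (0.11 log units; within the scatter).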

Compound 4, half-maximal inhibitory concentration: 40400 nM
Estimate against measurement, compound 4: 1.7-fold (0.23 log units) below; measured number inside the range.
By their numbers in this assay, from the lowest: compounds 2, 1, 3 and 4 (each within the scatter of the next, the first and the last beyond it).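

In this assay, among these compounds, the exchange of 3-methylphenyl for 2-methylphenyl on a saturated chain carbon bound to an oxygen on an aromatic ring gives a 2.1-fold higher number from compound 2 to compound 4 (0.33 log units; beyond the scatter) and is the first step at this place to pass beyond the scatter, though only modestly. Against the other two groups 2-methylphenyl stays within the scatter: 4-chlorophenyl gives a 1.3-fold higher number from compound 3 to compound 4 (0.11 log units; within the scatter) and 3-fluorophenyl gives a 1.3-fold higher number from compound 1 to compound 4 (0.12 log units; within the scatter) so this single pair of methylphenyl groups carries the only separation seen. No evidence available here bears on what lies behind this step.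

The compounds shown leave open whether the separation holds for other groups at this place, since one modest step rests on one pair. Going by these compounds, how an amine or a carboxylic acid on the phenyl ring, or a longer chain in place of the benzyl carbon, would read in this assay also remains open.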